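The source may hold more compounds than are shown below. What is called first, only, known or untested is meant among the compounds shown, and "the series" means these compounds.

Compound 1 `Nc1nc(OCC(F)(F)F)c2ncn(/C=C3/CC3(CO)CO)c2n1`: > 20000 nM
Compound 2 `CN(C)c1nc(N)nc2c1ncn2/C=C1/CC1(CO)CO`: > 20000 nM

In an ADME assay on CCRF-HSB-2 cells (Homo sapiens) for cytotoxicity, with a stated time of 7 days (on this read-out higher numbers stand for lower toxicity in this test and lower numbers for higher toxicity in this test), compound 1 gives > 20000 nM, which is a limit of the assay and not a number. Compound 2 gives > 20000 nM, also a limit and not a number. Compound 2 therefore stands at the limit of > 20000 nM in this assay, at which 2 of the 2 values shown sit, and no exact figure is available for it.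

Compound 3 `CCCSc1nc(N)nc2c1ncn2/C=C1/CC1(CO)CO` carries propylsulfanyl in place of dimethylamino on an aromatic carbon. For the measured compounds named here, only one measured step bears on this change: a step that the two limits leave unreadable from compound 1 to compound 2. It also exchanges the group on an aromatic carbon, with dimethylamino replacing 2,2,2-trifluoroethoxy, but its size and direction cannot be read. Neither compound 1 nor compound 2 has yet given a number, so the data offer no firm basis for a shift in either direction. No step beyond the scatter is expected in this assay. The expected step is a number no higher from compound 2 to compound 3 (the limit leaves the size open), and this estimate carries wide uncertainty. For compound 3 the estimated value is 20000 nM, with an expected range of 8000 nM to 50000 nM, and a further limit is the likeliest report.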

Compound 3, half-maximal cytotoxic concentration: 98000 nM
Estimate against measurement, compound 3: 4.9-fold (0.69 log units) below; measured number above the stated range.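

In this assay compound 3 gives 98000 nM. For the compounds shown here, no step from compound 1 or compound 2 to compound 3 can be read, because compound 1 and compound 2 each stand at a limit of the assay and not at a number: the limit of > 20000 nM in this assay, at which 2 of the 3 values shown sit. The compounds shown leave open how large the change is when propylsulfanyl replaces dimethylamino or 2,2,2-trifluoroethoxy on an aromatic carbon.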